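Pyrazin-2-yl to 1H-imidazol-4-yl: working notes

This account rests on a few compounds, and the source may have more. Where it says the series, first, only, none or still open, it means among the compounds named here.

Among the compounds with values here, in a physicochemical assay for acid dissociation, compound 2 `NCCCCCOC[C@H]1O[C@@H](OCCc2c[nH]c3ccccc23)[C@H](OCc2ccccc2)[C@@H](OCc2ccccc2)[C@@H]1OCc1cnccn1` gives 0.7 and holds the lower of the two numbers so far. Compound 1 `NCCCCCOC[C@H]1O[C@@H](OCCc2c[nH]c3ccccc23)[C@H](OCc2ccccc2)[C@@H](OCc2ccccc2)[C@@H]1OCc1ccccn1` gives 5.2 on the same scale. Within the data shown here, the one measured step runs a number 4.50 log units lower from compound 1 to compound 2 (beyond the scatter) and is large, with pyrazin-2-yl in place of pyridin-2-yl at the same place on the shared core.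

Compound 3 `NCCCCCOC[C@H]1O[C@@H](OCCc2c[nH]c3ccccc23)[C@H](OCc2ccccc2)[C@@H](OCc2ccccc2)[C@@H]1OCc1c[nH]cn1` changes that place again: 1H-imidazol-4-yl in place of pyrazin-2-yl on a saturated chain carbon bound to an oxygen on a saturated carbon with the rest of the structure untouched. Among the measured compounds shown here, no measured step brings in 1H-imidazol-4-yl, so there is no direct precedent. For the measured compounds named here, the single step above shows only that exchanging the ring at this place can move the number by a large amount. With compound 2 at 0.7 as the low end of the series, a move upward is the expected direction, and a large one, beyond the scatter. The expected change is a number 5.60 log units higher from compound 2 to compound 3 (beyond the scatter) and would place the new compound nearer compound 1 than compound 2. Compound 3 is estimated at 6.3 with an expected range from 5.5 to 7.1 on this scale.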

Compound 3, acid dissociation constant: 7.2
The estimate for compound 3 lay 0.90 log units below the measured number; the measured number lies above the stated range.
By their numbers in this assay, from the lowest: compound 2; then compound 1; then compound 3.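

In this assay, within the data shown here, 1H-imidazol-4-yl in place of pyrazin-2-yl gives a number 6.50 log units higher from compound 2 to compound 3 (beyond the scatter), the largest step so far in this short series, and 1H-imidazol-4-yl in place of pyridin-2-yl gives a number 2.00 log units higher from compound 1 to compound 3 (beyond the scatter). The earlier pair showed only a drop from the pyridin-2-yl compound, whereas this position is now seen to move the number in both directions from that compound: pyrazin-2-yl takes it down and 1H-imidazol-4-yl takes it up, with the rest of the structure untouched. The change also differs in kind from the earlier one, since a five-membered aromatic ring with 1 hydrogen-bond donor replaces a six-membered aromatic ring with 0 hydrogen-bond donors, but no measurement here gives a reason for the size or direction of either step.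

With only three rings at this place, the compounds shown cannot separate the contribution of ring size from that of the ring's donor hydrogen. A methyl group on the imidazole ring nitrogen in place of that hydrogen, or a plain phenyl ring at this place, would be the next structures to read against compound 3 and compound 1.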